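The source may hold more compounds than are shown below. What is called first, only, known or untested is meant among the compounds shown, and "the series" means these compounds.

Measured compounds in this series:

compound 1, `CCOC(=O)C1=C(C)OC2OC(COCc3ccccc3)C(OCc3ccccc3)C(OCc3ccccc3)C2[S+]1[O-]`: 250 nM
compound 2, `CCOC(=O)C1=C(C)OC2OC(COCc3ccccc3)C(OCc3ccccc3)C(O)C2[S+]1[O-]`: 790 nM
compound 3, `CCOC(=O)C1=C(C)OC2OC(CO)C(OCc3ccccc3)C(OCc3ccccc3)C2S1`: 4000 nM

All three were run in an assay on CHO cells for displacement of a labelled ligand from Substance-K receptor (Homo sapiens); a higher number here means a weaker inhibitor, a lower number a stronger inhibitor. Compound 2 differs from compound 1 by one change, (hydrogen in place of benzyl on an oxygen on a saturated carbon), and this gave a 3.2-fold higher number from compound 1 to compound 2 (0.50 log units; beyond the scatter). Compound 3 carries a different core from compound 1; the difference between the two cores is not broken down here. In this assay compound 3 has the highest number of the three, and its gaps to compound 2 and to compound 1 both lie beyond the scatter.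

Compound 4, `CCOC(=O)C1=C(C)OC2OC(CO)C(OCc3ccccc3)C(O)C2S1`, has not yet been measured. It differs from compound 3 by hydrogen in place of benzyl on an oxygen on a saturated carbon, which is the same change already seen from compound 1 to compound 2, at a place described in the same words. For compound 4 a step of a 3.0-fold higher number from compound 3 to compound 4 (0.48 log units; beyond the scatter) is expected in this assay, resting on the earlier step of a 3.2-fold higher number from compound 1 to compound 2 (0.50 log units; beyond the scatter) being repeated on the core of compound 3. Compound 4 is accordingly estimated at 12000 nM in this assay, with a likely range from 5000 nM to 30000 nM.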

Compound 4, inhibition constant: > 10000 nM
Compound 4: a limit, no number (the forecaster's own chance of this, stated with the estimate: 20%); the middle value does not contradict the limit.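

Compound 4 gives > 10000 nM in this assay, and this is a limit of the assay, not a number. The change from benzyloxy to hydroxy gives an at least 2.5-fold higher number from compound 3 to compound 4 (0.39 log units; beyond the scatter), so the direction of the step carries over from one core to the other, and the two steps can be set side by side: the same change on two cores in this assay, a 3.2-fold higher number (0.50 log units; beyond the scatter) from compound 1 to compound 2 and an at least 2.5-fold higher number (0.39 log units; beyond the scatter) from compound 3 to compound 4; the limit leaves it open whether they differ. Going by these compounds, the true size of the second step remains unknown, and two cores do not establish a rule for the wider series: the limit of > 10000 nM in this assay, at which 1 of the 4 values shown sits.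

The compounds shown leave open how the step behaves when that oxygen carries a methyl group or an acetyl group instead of benzyl or hydrogen, and how an amine in place of the hydroxy would read. They also leave open what the difference between the two cores contributes on its own, which the pairs shown do not break down.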